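This account rests on a few compounds, and the source may have more. Where it says the series, first, only, none or still open, it means among the compounds named here.

Of the compounds shown here, two of a shared core have been measured in a functional assay on HeLa cells (Homo sapiens) for cytotoxicity, read by MTT assay, with a stated time of 48 h; a lower number here means a stronger inhibitor, a higher number a weaker inhibitor. Compound 1, with the structure `CCOC(=O)c1c(-c2c(Cl)c3ccccc3oc2=O)nn(-c2ccc(Br)cc2)c1C(=O)OCC`, gives 500000 nM. Compound 2, with the structure `CCOC(=O)c1c(-c2cc3ccccc3oc2=O)nn(-c2ccc(C)c(C)c2)c1C(=O)OCC`, gives 50000 nM, the lower of the two numbers and set apart from compound 1 by a gap well beyond the scatter. These two compounds differ in more than one place, so no single change can be credited with that gap.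

Compound 3, with the structure `CCOC(=O)c1c(-c2cc3ccccc3oc2=O)nn(-c2ccc(Cl)cc2)c1C(=O)OCC`, has not yet been measured. It carries 4-chlorophenyl in place of 3,4-dimethylphenyl on an aromatic nitrogen. For the measured compounds named here, because compound 1 gives 500000 nM and is the only halogenated aryl analogue seen, a weakening relative to compound 2 is expected, but a modest one, since other parts of compound 1 also differ. The step from compound 2 to compound 3 is estimated as a 2.0-fold higher number from compound 2 to compound 3 (0.30 log units; within the scatter). For compound 3 the expected value in this assay is 100000 nM, within a range of 30000 nM to 400000 nM.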

Compound 3, half-maximal inhibitory concentration: 87000 nM
Beside the measured number, compound 3's estimate is 1.1-fold (0.06 log units) above it, within the range that was stated.
By their numbers in this assay, from the lowest: compounds 2 and 3 (each within the scatter of the next); then compound 1.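

For the compounds shown here, compound 2 and compound 3 differ in one place only, so they give the first clean comparison here: in this assay, 4-chlorophenyl in place of 3,4-dimethylphenyl on the aromatic nitrogen gives a 1.7-fold higher number from compound 2 to compound 3 (0.24 log units; within the scatter) and the two compounds cannot be told apart. Within this pair, then, the nitrogen substituent can be either of these two aryl groups with no change beyond the scatter. The step from compound 1 to either of the others still cannot be read, since compound 1 differs from each in more than one place, and nothing shown explains why the two aryl groups read alike.

Open, going by these compounds, is whether an amine or a carboxylic acid on this phenyl ring would shift the number beyond the scatter. So too is what a longer alkyl chain in place of the ring would do.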